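A few compounds are considered here, and "the series" means these few. Any claim that something is new, unique, unknown or untested is made for them only; others in the source may bear on it.

Compound 1 `O=C(Nc1ccccc1)OC1CCCN(Cc2ccccc2)C1`: > 100000 nM in an assay on BTI-TN-5B1-4 cells for inhibition of Amine oxidase [flavin-containing] A (Homo sapiens), read by fluorescence and Amplex Red, using microsomes, with a stated time of 15 min (on this read-out lower numbers stand for stronger inhibition and higher numbers for weaker inhibition), a limit of the assay and not a number.
Compound 2 `C#CCN1CCC(COC(=O)N(C)CC)CC1`: > 100000 nM in this assay, again only a limit.

Compound 2 therefore stands at the limit, where both values shown sit (the limit of > 100000 nM in this assay, at which 2 of the 2 values shown sit). Within the data shown here, no pair of measured compounds differing in one place is available, so no measured step size can be read from the set.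

Compound 3 `CCN(C)C(=O)OCC1CCN(Cc2ccccc2)CC1` differs from compound 2 by phenyl in place of ethynyl on a saturated chain carbon bound to an amine nitrogen in a ring. Compound 1 already carries a phenyl on a saturated chain carbon bound to a ring amine nitrogen and also sits only at the limit (the limit of > 100000 nM in this assay, at which 2 of the 2 values shown sit), so nothing measured points to a gain in potency from this change.

The step from compound 2 to compound 3 is expected to be a step that the limit leaves unreadable from compound 2 to compound 3, which is no step beyond the scatter, with the result most likely reported again as a limit. Compound 3 is estimated at 150000 nM, in the range 30000 nM to 1000000 nM.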

Compound 3, half-maximal inhibitory concentration: > 100000 nM
Compound 3: a limit, no number; the forecaster's own chance of this, stated with the estimate: 80%; the middle value does not contradict the limit.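

Among these compounds, compound 2 and compound 3 each give only a limit of the assay, not a number, so no step between them can be read: the limit of > 100000 nM in this assay, at which 3 of the 3 values shown sit.

The compounds shown leave open which structural change, if any, would give a measurable value in this assay.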